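The source may report more compounds than this note shows. Statements on the series, on what has been measured and on what is new or still open speak of the compounds shown alone.

Measured compounds:
compound 1 `CC(C)c1n[nH]c2c(NCc3ccc(-c4ccccn4)cc3)nc(SC3CCCCC3O)nc12`, 636 nM
compound 2 `CNCCSc1nc(NCc2ccc(-c3ccccn3)cc2)c2[nH]nc(C(C)C)c2n1`, 56 nM
compound 3 `C=CCSc1nc(NCc2ccc(-c3ccccn3)cc2)c2[nH]nc(C(C)C)c2n1`, 1010 nM

In a functional assay on HT cells (Homo sapiens) for antiproliferative activity, read by fluorescence, with a stated time of 72 h (on this read-out lower numbers stand for stronger inhibition of growth and higher numbers for weaker inhibition of growth), compound 1 gives the second highest of the three numbers; compound 3 lies nearest, a 1.6-fold higher number from compound 1 to compound 3 (0.20 log units; within the scatter), and compound 2 furthest, an 11-fold lower number from compound 1 to compound 2 (1.06 log units; beyond the scatter). Compound 4 `CC(C)c1n[nH]c2c(NCc3ccc(-c4ccccn4)cc3)nc(SCC(C)(C)N)nc12` differs from compound 1 in one place: 2-amino-2-methylpropyl in place of 2-hydroxycyclohexyl on a sulfur. Going by the values given here, the step that bears most on it is the one to compound 2, where an open chain carrying a nitrogen also replaced the 2-hydroxycyclohexyl and gave an 11-fold lower number from compound 1 to compound 2 (1.06 log units; beyond the scatter); the allyl chain of compound 3, by contrast, gave only a 1.6-fold higher number from compound 1 to compound 3 (0.20 log units; within the scatter), and an 18-fold higher number from compound 2 to compound 3 (1.26 log units; beyond the scatter) shows the same contrast. A lower number is therefore expected for compound 4, with a step of about a 5.8-fold lower number from compound 1 to compound 4 (0.76 log units; beyond the scatter). Compound 4 is estimated at 110 nM, between 40 nM and 320 nM.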

Compound 4, concentration for 50% growth inhibition: 85 nM
Estimate against measurement, compound 4: 1.3-fold (0.11 log units) above; the range from low to high includes it.
By their numbers in this assay, from the lowest: compounds 2 and 4 (each within the scatter of the next); then compounds 1 and 3 (each within the scatter of the next).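

In this assay the lower numbers are not confined to the 2-(methylamino)ethyl chain of compound 2, since 2-amino-2-methylpropyl on the same sulfur gives a 7.5-fold lower number from compound 1 to compound 4 (0.87 log units; beyond the scatter) and also a 12-fold lower number from compound 3 to compound 4 (1.07 log units; beyond the scatter) in this set. The two open chains carrying a nitrogen cannot be told apart here, with a 1.5-fold higher number from compound 2 to compound 4 (0.18 log units; within the scatter) as the step between them. Nothing measured here accounts for these steps.

Going by these compounds, it remains open whether the nitrogen itself matters or only the loss of the ring, which a 2-hydroxy-2-methylpropyl chain would separate. On these data alone, how a tertiary amine or a longer chain ending in an amine would compare also remains open.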